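This account rests on a few compounds, and the source may have more. Where it says the series, first, only, none or still open, it means among the compounds named here.

Compound 3 `Brc1ccc2ccn(CCN3CCCN(C4CCCC4)CC3)c2c1` stands highest of the three numbers measured in an assay on HEK293 cells for binding affinity to 5-hydroxytryptamine receptor 7 (Homo sapiens), read by radioligand binding, tested at 1 uM (on this read-out higher numbers stand for more inhibition at the one concentration tested (going by the name of the read-out) and lower numbers for less inhibition), where compound 3 gives 98%. Its nearest neighbour is compound 1 `CN1CCCN(CCn2ccc3ccc(Br)cc32)CC1`, which gives 93% in this assay, and the furthest is compound 2 `CC(C)(C)CN1CCCN(CCn2ccc3ccc(Br)cc32)CC1`, which gives 70%. The two steps that lead to compound 3 both change the group on the same ring nitrogen: a number 5 percentage points higher from compound 1 to compound 3 (within the scatter), and a number 28 percentage points higher from compound 2 to compound 3 (beyond the scatter). Compound 4 `Brc1ccc2ccn(CCN3CCCN(c4ccccc4)CC3)c2c1` differs from compound 3 by phenyl in place of cyclopentyl on an amine nitrogen in a ring. Going by the values given here, no measured step exchanges one ring for another on this nitrogen, so the bearing of the earlier steps is indirect: methyl and cyclopentyl sit within the scatter of each other, while neopentyl, a branched chain, falls away. A phenyl ring in place of cyclopentyl is therefore expected to stay near the numbers of compounds 1 and 3, with a step of a number 10 percentage points lower from compound 3 to compound 4 (within the scatter) expected to stay within the scatter. Compound 4 is thus estimated at 88%, in a range from 65% to 99%.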

Compound 4, a percentage reported as inhibition, at one concentration (the size of the read-out at that concentration, not a potency): 18%
Compound 4: middle estimate off by 70 percentage points, on the high side, and the stated range ends above it.
By their numbers in this assay, from the lowest: compound 4; then compound 2; then compounds 1 and 3 (each within the scatter of the next).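

At this amine nitrogen in the seven-membered ring, this assay separates phenyl sharply from the saturated carbon groups: there is a number 80 percentage points lower from compound 3 to compound 4 (beyond the scatter), a number 75 percentage points lower from compound 1 to compound 4 (beyond the scatter), and a number 52 percentage points lower from compound 2 to compound 4 (beyond the scatter). The earlier compounds shown here showed only a modest spread, with methyl and cyclopentyl within the scatter of each other and neopentyl lower, whereas the phenyl compound 4 now lies beyond the scatter below all three, including neopentyl. Exchanging the five-membered non-aromatic ring for the six-membered aromatic ring therefore has a much larger effect here than any change among the saturated groups, though no measurement offered here accounts for the drop.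

The compounds shown leave open whether a cyclohexyl or benzyl group on this nitrogen would stay with the saturated groups or fall with phenyl. They also leave open whether a pyridyl ring would match phenyl.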